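This account rests on a few compounds, and the source may have more. Where it says the series, first, only, none or still open, it means among the compounds named here.

Measured in a functional assay for inhibition, with Homo sapiens as the target; on this read-out higher numbers stand for weaker inhibition and lower numbers for stronger inhibition:
- compound 1 `COc1cc(OC)c(C(=O)/C=C/c2ccc([N+](=O)[O-])cc2)c(OC)c1`: 407 nM
- compound 2 `COC(=O)c1ccccc1C(=O)/C=C/c1ccccc1`: 1950 nM

Compound 2, at 1950 nM, holds the higher number of the pair and so shows the weaker inhibition. The gap down to compound 1 lies beyond the scatter. Compound 3 `CN(C)c1ccccc1C(=O)/C=C/c1ccccc1` has not yet been measured. It differs from compound 2 by having dimethylamino in place of methoxycarbonyl on an aromatic carbon, ortho to a large group (dimethylamino in place of methoxycarbonyl on an aromatic carbon). Among the compounds with values here, the two measured compounds differ in more than one place, so no measured step speaks directly to this change. With so little to go on, no shift beyond the scatter is expected in this assay, and no firm direction can be argued. The expected change is a 1.1-fold higher number from compound 2 to compound 3 (0.05 log units; within the scatter). The estimate for compound 3 is 2200 nM, with an expected range of 700 nM to 7000 nM.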

Compound 3, half-maximal inhibitory concentration: 1770 nM
Compound 3: middle estimate off by 1.2-fold (0.09 log units), on the high side, and the stated range covers the measured number.
By their numbers in this assay, from the lowest: compound 1; then compounds 3 and 2 (each within the scatter of the next).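

In this assay, replacing methoxycarbonyl with dimethylamino on this aromatic carbon, ortho to a large group, gives a 1.1-fold lower number from compound 2 to compound 3 (0.04 log units; within the scatter). This is the only one-place step among the compounds shown, and it indicates that these two groups are interchangeable at this position in this assay, even though they differ in heavy atoms and in hydrogen-bond acceptors. No measurement shown here explains why the swap leaves the number within the scatter.

The compounds shown leave open whether a carboxylic acid or a primary amine on this carbon would also stay within the scatter of compound 2 and compound 3. They also leave open whether a plain hydrogen there, with neither group present, would give a similar number.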